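Compound 4: replacing the dimethoxyphenyl amide group

The source may hold more compounds than are shown below. What is called first, only, known or untested is meant among the compounds shown, and "the series" means these compounds.

compound 1 `COc1ccc(NC(=O)CN2CCN(c3nnc(Cc4ccncc4)c4ccccc34)CC2)cc1OC`: 40100 nM
compound 2 `O=C(CN1CCN(c2nnc(Cc3ccccc3)c3ccccc23)CC1)Nc1c(F)cccc1F`: 19700 nM
compound 3 `COc1ccc(NC(=O)CN2CCN(c3nnc(Cc4ccccc4)c4ccccc34)CC2)cc1OC`: 145000 nM

In a functional assay on HT-29 cells (Homo sapiens) for cytotoxicity, read by MTT assay, with a stated time of 72 h (a lower number here means a stronger inhibitor, a higher number a weaker inhibitor), compound 1 gives 40100 nM, the second highest of the three numbers. Compound 2 reads lower at 19700 nM. Compound 3 reads higher at 145000 nM.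

The next step leads to compound 4 `Cc1ccc(F)cc1NC(=O)CN1CCN(c2nnc(Cc3ccncc3)c3ccccc23)CC1`: 5-fluoro-2-methylphenyl in place of 3,4-dimethoxyphenyl on an amide-type nitrogen. In words, 5-fluoro-2-methylphenyl stands in place of 3,4-dimethoxyphenyl on an amide-type nitrogen, while the pyridin-4-yl group stays.

Among the compounds with values here, two measured steps bear on this. The closer is a 7.4-fold higher number from compound 2 to compound 3 (0.87 log units; beyond the scatter), with 3,4-dimethoxyphenyl in place of 2,6-difluorophenyl on an amide-type nitrogen. Read in reverse, it points to a lower number on leaving 3,4-dimethoxyphenyl. That step was measured with phenyl rather than pyridin-4-yl, however, and its other group is not the one entering here. The second, a 3.6-fold higher number from compound 1 to compound 3 (0.56 log units; beyond the scatter), shows that the number also moves with the exchange of pyridin-4-yl for phenyl, so the first step need not carry over in full. Within the data shown here, no measured compound carries 5-fluoro-2-methylphenyl.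

A lower number is therefore expected in this assay, though by less than the closer step. The expected move is a 2.7-fold lower number from compound 1 to compound 4 (0.43 log units; beyond the scatter). For compound 4 the estimate is 15000 nM, with an expected range of 5000 nM to 45000 nM.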

Compound 4, half-maximal inhibitory concentration: 470 nM
Compound 4: middle estimate off by 32-fold (1.50 log units), on the high side, outside the stated range (below it).
By their numbers in this assay, from the lowest: compound 4; then compound 2; then compound 1; then compound 3.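

In this assay, an 85-fold lower number from compound 1 to compound 4 (1.93 log units; beyond the scatter) is a large step, whereas the earlier step at this position, a 7.4-fold higher number from compound 2 to compound 3 (0.87 log units; beyond the scatter), and the step at the pyridin-4-yl position, a 3.6-fold higher number from compound 1 to compound 3 (0.56 log units; beyond the scatter), are both modest. Within the data shown here, the aryl group on the amide-type nitrogen can therefore move the number much further than the earlier compounds showed, and compound 4 at 470 nM shows this with pyridin-4-yl retained. The change removes the methoxy groups of 3,4-dimethoxyphenyl and brings in a fluorine and a methyl together, but no measurement available here explains the size of the step.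

The compounds shown cannot separate the contributions of the fluorine and the methyl, and they do not show whether a chlorine or an amine on this aryl ring would give a similar number. They also leave open whether 5-fluoro-2-methylphenyl gives a step of this size when phenyl stands in place of pyridin-4-yl.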